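A few compounds are considered here, and "the series" means these few. Any claim that something is new, unique, unknown or untested is made for them only; others in the source may bear on it.

Working notes on the benzoxaborole amide series.

Going by the values given here, compound 2 `O=C(CCc1cccc2c1B(O)OC2)Nc1cccc(-c2cccc(Cl)c2)c1` is one of two members so far measured in an ADME assay on WI-38 cells (Homo sapiens) for cytotoxicity, read by MTT assay, with a stated time of 72 h; a higher number here means a weaker inhibitor, a lower number a stronger inhibitor. In this assay compound 2 gives 58000 nM, the highest of the two numbers, with compound 1 `O=C(CCc1cccc2c1B(O)OC2)Nc1cccc(-c2cccc(F)c2)c1` nearest: in this assay compound 1 gives 37000 nM. Among the compounds with values here, the only step between measured compounds, a 1.6-fold higher number from compound 1 to compound 2 (0.20 log units; within the scatter), is the one in which chloro replaces fluoro on an aromatic carbon, and it lies within the scatter.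

Compound 3 `N#Cc1cccc(-c2cccc(NC(=O)CCc3cccc4c3B(O)OC4)c2)c1` is not yet measured in this assay. It differs from compound 2 as follows: cyano in place of chloro on an aromatic carbon. Within the data shown here, no measured step bears directly on this exchange; the one step available, a 1.6-fold higher number from compound 1 to compound 2 (0.20 log units; within the scatter), concerns a different pair of substituents at the same place and gave no movement beyond the scatter. On that basis nothing beyond the scatter is expected here either, and the step of a 1.2-fold lower number from compound 2 to compound 3 (0.06 log units; within the scatter) is an estimate, not a reading. For compound 3 in this assay the expected number is therefore 50000 nM, within a range of 20000 nM to 125000 nM.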

Compound 3, half-maximal inhibitory concentration: 7300 nM
The estimate for compound 3 lay 6.8-fold (0.84 log units) above the measured number; the measured number lies below the stated range.
By their numbers in this assay, from the lowest: compound 3; then compounds 1 and 2 (each within the scatter of the next).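

In this assay, the place on the aromatic carbon, meta to a large group, turns out not to be indifferent to its substituent: a 7.9-fold lower number from compound 2 to compound 3 (0.90 log units; beyond the scatter) with cyano in place of chloro, and a 5.1-fold lower number from compound 1 to compound 3 (0.70 log units; beyond the scatter) with cyano in place of fluoro, whereas fluoro and chloro stay within the scatter of each other. Going by these compounds alone, compound 3 therefore stands apart from both halogen compounds, and the change from 3-chlorophenyl to 3-cyanophenyl is the first to move the number beyond the scatter, with the entering group counting one more heavy atom, a triple bond and a hydrogen-bond acceptor. No measurement at hand accounts for this step.

Going by these compounds, with a single nitrile, it remains open whether a methoxy group, an amine or a carboxylic acid at this place would give a number near that of compound 3 or stay with compounds 1 and 2. It also remains open whether the step from chloro to cyano would hold on a core other than the shared core of these compounds.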